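The compounds below may be only part of what the source reports. "The series", "measured", "known", "first", "only" and "open" are said of these compounds alone.

Among the compounds with values here, compound 1, `CCCOc1c(-c2cc(OC)c(OC)c(OC)c2)oc2ccccc2c1=O`, is the one member of this set that gives a number in a functional assay on DU-145 cells (Homo sapiens) for antiproliferative activity, read by WST assay, with a stated time of 3 days (on this read-out higher numbers stand for weaker inhibition and lower numbers for stronger inhibition), with compound 1 at 2800 nM. Compound 2, `CCC(C)Oc1c(-c2cc(OC)c(OC)c(OC)c2)oc2ccccc2c1=O`, reaches only the limit of this assay, and compound 2 stands at > 50000 nM. Compound 3, `CCCN(CCC)CCCOc1c(-c2cc(OC)c(OC)c(OC)c2)oc2ccccc2c1=O`, likewise reaches only a limit in this assay, where compound 3 stands at > 50000 nM. Both of the steps away from compound 1 are therefore large: an at least 17-fold higher number from compound 1 to compound 2 (1.25 log units; beyond the scatter), and an at least 17-fold higher number from compound 1 to compound 3 (1.25 log units; beyond the scatter). The two limits meet in the limit of > 50000 nM in this assay, at which 2 of the 3 values shown sit.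

Compound 4, `CCCN(CCC)CCCCCOc1c(-c2cc(OC)c(OC)c(OC)c2)oc2ccccc2c1=O`, is not yet measured. It differs from compound 1 by 2-(dipropylamino)ethyl in place of hydrogen on a saturated chain carbon, three bonds along the chain from an oxygen on an aromatic ring. Within the data shown here, the step that bears on it most directly is the one from compound 1 to compound 3, where the same dipropylamino group enters on a shorter chain and the number climbs to the limit. On that basis a large rise in this assay is expected for compound 4 as well, with a considerable chance that only a limit is reported; the expected step is a 14-fold higher number from compound 1 to compound 4 (1.15 log units; beyond the scatter). Compound 4 is accordingly estimated at 40000 nM, within a range from 8000 nM to 200000 nM.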

Compound 4, half-maximal inhibitory concentration: 24200 nM
Compound 4: middle estimate off by 1.7-fold (0.22 log units), on the high side; the range from low to high includes it.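

Compound 4 returns a number in this assay rather than a limit, so a dipropylamino group carried on a chain at this oxygen does not in itself push the read-out to the limit, as compound 3 alone might have suggested. The change still costs activity relative to the plain propyl ether, with an 8.6-fold higher number from compound 1 to compound 4 (0.94 log units; beyond the scatter), so compound 1 keeps the lowest number of the compounds that give one. Against the two compounds that stop at a limit the number moves down, with an at least 2.0-fold lower number from compound 3 to compound 4 (0.31 log units; beyond the scatter) and an at least 2.0-fold lower number from compound 2 to compound 4 (0.31 log units; beyond the scatter), and both of these steps give only a minimum size, their far ends being limits rather than numbers: the limit of > 50000 nM in this assay, at which 2 of the 4 values shown sit.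

With only the 3-(dipropylamino)propyl and 5-(dipropylamino)pentyl chains shown, two lengths cannot establish a trend, and it remains open whether a longer chain would lower the number further or whether the drop to compound 4 is an isolated case. Also open, going by these compounds, is how a smaller amine such as dimethylamino, or a carboxylic acid, at the end of the same chain would compare with dipropylamino and with the plain propyl ether of compound 1.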